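The compounds below may be only part of what the source reports. "The series", "measured", "known", "first", "only" and "open" are said of these compounds alone.

Working notes on the series. In a functional assay on CHO cells (Homo sapiens) for antiproliferative activity against CHO (Cricetulus griseus), read by sulforhodamine B assay, with a stated time of 48 h (on this read-out higher numbers stand for weaker inhibition and lower numbers for stronger inhibition), compound 1 `Cc1cccc(NS(=O)(=O)c2ccc(N3CCNC3=O)cc2)c1` gives 230 nM. Among the measured compounds shown here, compound 2 `COc1cc(NS(=O)(=O)c2ccc(N3CCNC3=O)cc2)cc(OC)c1OC` gives 190 nM, and the two numbers lie within the scatter of each other, so compound 1 cannot be separated from the only other measured member.

The next member is compound 3 `O=C1NCCN1c1ccc(S(=O)(=O)Nc2cccc(Br)c2)cc1`. It keeps the core of compound 1 and has bromo in place of methyl on an aromatic carbon, meta to a large group, taking 3-methylphenyl to 3-bromophenyl (bromo in place of methyl on an aromatic carbon).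

For the measured compounds named here, no measured pair shows a single change of this kind, so the data give no direct size for the step. In this assay no shift beyond the scatter is expected, and no direction is favoured. This expectation rests on compound 1 at 230 nM as the starting point, and the range is kept wide to reflect the lack of a direct precedent. The estimated step of a 1.2-fold lower number from compound 1 to compound 3 (0.06 log units; within the scatter) is expected to stay small. In this assay the estimate for compound 3 is 200 nM, with an expected range of 80 nM to 500 nM.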

Compound 3, half-maximal inhibitory concentration: 250 nM
The estimate for compound 3 lay 1.3-fold (0.10 log units) below the measured number; low and high end bracket the measured number.
By their numbers in this assay, from the lowest: compounds 2, 1 and 3 (each within the scatter of the next).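

In this assay the step of a 1.1-fold higher number from compound 1 to compound 3 (0.04 log units; within the scatter) gives the first direct size for a single change at this position: bromo in place of methyl on an aromatic carbon, meta to a large group, moves the number by no more than the scatter. The 3-methylphenyl and 3-bromophenyl members therefore cannot be separated in this assay, and the position tolerates this one exchange with no shift that can be resolved, a statement that rests on this single pair and extends to no other group. Nothing measured in the series bears on why the two groups read alike.

As far as these compounds go, it remains open whether the number at this position would stay within the scatter with a group of a different kind, such as an amine, a carboxylic acid or a longer chain. Also open, from the compounds shown here alone, is whether a nitrile or a hydroxyl in the same place would give a step beyond the scatter, and whether the exchange of bromo for methyl reads the same way on a different core.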